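The source may report more compounds than this note shows. Statements on the series, on what has been measured and on what is new or still open speak of the compounds shown alone.

Measured compounds:
- compound 1, `O=C1C[C@H](OCc2cn(C(=O)c3ccccc3)nn2)[C@H]2CO[C@@H]1O2`: 25900 nM in a functional assay on MDA-MB-231 cells (Homo sapiens) for cytotoxicity, read by MTT assay, with a stated time of 48 h; on this read-out higher numbers stand for weaker inhibition and lower numbers for stronger inhibition
- compound 2, `CCCCn1cc(CO[C@H]2CC(=O)[C@@H]3OC[C@H]2O3)nn1`: 27900 nM in this assay

On the two numbers in hand, compound 2 stands alongside compound 1 with no separation of note: the step of a 1.1-fold higher number from compound 1 to compound 2 (0.03 log units; within the scatter) places the two values within the scatter of each other, so neither is called the weaker or the stronger.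

Compound 3, `O=C1C[C@H](OCc2cn(C3CCCCC3)nn2)[C@H]2CO[C@@H]1O2`, differs from compound 2 by cyclohexyl in place of butyl on an aromatic nitrogen. Within the data shown here, the only measured step touching this position is the one from compound 1 to compound 2, which exchanged benzoyl for butyl on the aromatic nitrogen and moved the number by a 1.1-fold higher number from compound 1 to compound 2 (0.03 log units; within the scatter). That exchange of groups at the same aromatic nitrogen left the read-out essentially unchanged. Among the measured compounds shown here, no measured pair speaks to cyclohexyl itself. On this basis the step from compound 2 to compound 3 in this assay is expected to be a 1.0-fold lower number from compound 2 to compound 3 (0.01 log units; within the scatter), that is, nothing beyond the scatter in either direction. Compound 3 is therefore expected to give about 27000 nM, with a range of 12000 nM to 60000 nM.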

Compound 3, half-maximal inhibitory concentration: 24300 nM
Estimate against measurement, compound 3: 1.1-fold (0.05 log units) above; the measured number falls inside the stated range.
By their numbers in this assay, from the lowest: compounds 3, 1 and 2 (each within the scatter of the next).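

Cyclohexyl on the aromatic nitrogen adds a non-aromatic carbon ring to the groups compared at this position, and in this assay the step stays within the scatter on both comparisons: a 1.1-fold lower number from compound 2 to compound 3 (0.06 log units; within the scatter) and a 1.1-fold lower number from compound 1 to compound 3 (0.03 log units; within the scatter). Compound 1, compound 2 and compound 3 therefore show no separation across benzoyl, butyl and cyclohexyl, whereas the earlier pair covered only benzoyl and butyl. Nothing available explains this lack of separation.

Open, on these data alone, is whether an amine or a carboxylic acid carried on this nitrogen, or a chain longer than butyl, would give a step beyond the scatter. Among these compounds, also open is whether the same lack of separation would hold on a core other than the one shared by these compounds, or in cells other than those of this read-out.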